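Carbamate in Place of Ethyl in a Pancreatic Cell Assay

A few compounds are considered here, and "the series" means these few. Any claim that something is new, unique, unknown or untested is made for them only; others in the source may bear on it.

Compound 1, `CCOc1cc(=O)n(CCCO)c2c1CC(CC=C(C)C)C(C)(C)C2`: 66.5%
Compound 2, `CCOc1cc(=O)n(CCCO)c2c1CC(C/C=C(\C)CCC=C(C)C)C(C)(C)C2`: 67.8%
Compound 3, `CC(C)=CCC/C(C)=C/CC1Cc2c(OCCCNS(=O)(=O)c3ccc(Cl)cc3)cc(=O)n(CCCO)c2CC1(C)C`: 14.5%

These numbers come from a functional assay on PANC-1 cells (Homo sapiens) for inhibition, read by MTT assay, with a stated time of 24 h, tested at 10 uM; on this read-out higher numbers stand for more inhibition at the one concentration tested (going by the name of the read-out) and lower numbers for less inhibition. Compound 2 has the highest of the three, yet the step of a number 1.3 percentage points higher from compound 1 to compound 2 (within the scatter) lies within the scatter, so compound 1 and compound 2 cannot be told apart; compound 3 sits far lower, as the step of a number 53.3 percentage points lower from compound 2 to compound 3 (beyond the scatter) shows. Compound 4, `COc1cccc(NC(=O)Oc2cc(=O)n(CCCO)c3c2CC(C/C=C(\C)CCC=C(C)C)C(C)(C)C3)c1`, differs from compound 2 in one place: (3-methoxyphenyl)carbamoyl in place of ethyl on an oxygen on an aromatic ring. Going by the values given here, no measured step touches this oxygen. Among the compounds with values here, the only precedent is the step of a number 53.3 percentage points lower from compound 2 to compound 3 (beyond the scatter), where a (((4-chlorophenyl)sulfonyl)amino)methyl group entering on a saturated chain carbon cut inhibition sharply. On that single, indirect precedent a decrease is expected in this assay, with wide uncertainty. Compound 4 is therefore estimated at 40%, between 15% and 65%, an expected step of a number 27.8 percentage points lower from compound 2 to compound 4 (beyond the scatter).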

Compound 4, a percentage reported as inhibition, at one concentration (the size of the read-out at that concentration, not a potency): 47%
Compound 4: the middle estimate sits 7 percentage points below what was measured; the range from low to high includes it.
By their numbers in this assay, from the lowest: compound 3; then compound 4; then compounds 1 and 2 (each within the scatter of the next).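

Replacing ethyl with (3-methoxyphenyl)carbamoyl on an oxygen on an aromatic ring gives a number 20.8 percentage points lower from compound 2 to compound 4 (beyond the scatter) in this assay. The drop is real, yet a much larger group that brings an aromatic ring and a hydrogen-bond donor still leaves measurable inhibition at this oxygen. No evidence shown explains the drop. The compounds shown leave open whether the carbamoyl link or the 3-methoxyphenyl ring drives the change. An acetyl group or a plain phenylcarbamoyl group on this oxygen would help separate the two.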